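This account rests on a few compounds, and the source may have more. Where it says the series, first, only, none or still open, it means among the compounds named here.

Measured so far in a functional assay on HT-29 cells (Homo sapiens) for antiproliferative activity, read by MTT assay, with a stated time of 96 h; on this read-out higher numbers stand for weaker inhibition and lower numbers for stronger inhibition:
- Compound 1 `S=C(N/N=C1\CC2(CCCCC2)Oc2c1ccc1ccccc21)N1CCNCC1`: 8340 nM
- Compound 2 `S=C(N/N=C1\CC2(CCCCC2)Oc2c1ccc1ccccc21)N1CCOCC1`: 9310 nM

Compound 2 cannot be separated from compound 1 on these numbers. Among the compounds with values here, the only measured step, a 1.1-fold higher number from compound 1 to compound 2 (0.05 log units; within the scatter), lies within the scatter and places morpholin-4-yl in place of piperazin-1-yl on a thiocarbonyl carbon.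

The next compound, compound 3 `N/N=C1\CC2(CCCCC2)Oc2c1ccc1ccccc21`, differs from compound 2 by a hydrogen atom in place of a group of 8 heavy atoms (5 carbon, 1 nitrogen, 1 oxygen, 1 sulfur; one six-membered non-aromatic ring with 2 hetero atoms), on an amine nitrogen. This change removes the thiocarbonyl carbon together with its ring, so it goes further than the exchange already measured. The measured step therefore bears on it only in part. It shows that swapping one ring for the other made no difference beyond the scatter in this assay, but it says nothing about losing the whole group. Within the data shown here, no measured compound lacks that group, so the data favour no direction. The expectation is no step beyond the scatter, held loosely and with a wide range. The expected step is a 1.1-fold higher number from compound 2 to compound 3 (0.03 log units; within the scatter). For compound 3 the estimated value is 10000 nM, with an expected range from 3000 nM to 35000 nM.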

Compound 3, half-maximal inhibitory concentration: 9970 nM
Beside the measured number, compound 3's estimate is 1.0-fold (0.00 log units) above it, within the range that was stated.
By their numbers in this assay, from the lowest: compounds 1, 2 and 3 (each within the scatter of the next).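

In this assay, replacing the whole thiocarbonyl group and its ring on the amine nitrogen with a hydrogen atom gives a 1.1-fold higher number from compound 2 to compound 3 (0.03 log units; within the scatter) for the morpholin-4-yl group and a 1.2-fold higher number from compound 1 to compound 3 (0.08 log units; within the scatter) for the piperazin-1-yl group. Within the data shown here, the earlier exchange tested only one ring against the other, whereas these two steps test the whole group against a hydrogen atom, and neither separates the compounds. At this position, then, neither group can be told from a hydrogen atom on these numbers, and all three compounds stand within the scatter of one another. No independent evidence bears on this result.

The compounds shown leave open whether any other group on this amine nitrogen, such as an acetyl group, a longer alkyl chain or a thiocarbonyl carrying an open-chain dimethylamine, would give a step beyond the scatter. As far as these compounds go, all three compounds also share the core of compound 1, so it remains open whether a change elsewhere, such as a hydroxyl or an amine on that core, would shift the number in this assay more than the changes at this nitrogen have.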